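Trimming a catechol: from compound 1 to compound 4

A few compounds are considered here, and "the series" means these few. Any claim that something is new, unique, unknown or untested is made for them only; others in the source may bear on it.

Compound 1 `O=C(C1=C(O)/C(=C/c2ccc(O)c(O)c2)CCC1)c1ccccc1`: 55.9%
Compound 2 `O=C1/C(=C/c2ccccc2)CCC/C1=C\c1ccc(O)cc1`: 53%
Compound 3 `O=C1/C(=C/c2ccccc2)CCC/C1=C\c1ccc(F)cc1`: 34%

In an assay on isolated protein for inhibition of Alpha glucosidase (Homo sapiens), with stated times of 5 min and 15 min, tested at 50 uM (a lower number here means less inhibition, a higher number more inhibition at the concentration tested (going by the name of the read-out)), compound 1 stands highest of the three numbers shown; compound 2 lies within the scatter of it, while compound 3 sits beyond the scatter below it. Compound 4 `O=C(C1=C(O)/C(=C/c2ccc(O)cc2)CCC1)c1ccccc1` differs from compound 1 by hydrogen in place of hydroxy on an aromatic carbon. Among the measured compounds shown here, only one measured step changes a single place, a number 19 percentage points lower from compound 2 to compound 3 (beyond the scatter), and it removes a hydroxy on a different core in favour of fluoro rather than hydrogen; it bears on the present step only loosely, but it points downward when an aromatic hydroxy is lost. Compound 4 is therefore expected to give 45%, with a range from 30% to 60%. The estimated step of a number 10.9 percentage points lower from compound 1 to compound 4 (beyond the scatter) would be modest and at the edge of the scatter.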

Compound 4, a percentage reported as inhibition, at one concentration (the size of the read-out at that concentration, not a potency): 34.9%
Compound 4: middle estimate off by 10.1 percentage points, on the high side; the range from low to high includes it.
By their numbers in this assay, from the lowest: compounds 3 and 4 (each within the scatter of the next); then compounds 2 and 1 (each within the scatter of the next).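

In this assay, going from 3,4-dihydroxyphenyl to 4-hydroxyphenyl gives a number 21 percentage points lower from compound 1 to compound 4 (beyond the scatter), which shows that on the core of compound 1 the inhibition depends on the hydroxy ortho to a hydroxy group. Unlike the earlier step, this one replaces the hydroxy with plain hydrogen and leaves the rest of the structure unchanged. No evidence here accounts for the size of this step. From the compounds shown here alone, whether a methoxy group or an amine on this aromatic carbon would retain the inhibition of compound 1 remains open, as does the contribution of the remaining hydroxy on this core.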